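The source may report more compounds than this note shows. Statements on the series, on what has been measured and on what is new or still open speak of the compounds shown alone.

In an ADME assay on HepG2 cells (Homo sapiens) for cytotoxicity, read by MTT assay, with a stated time of 72 h (on this read-out higher numbers stand for lower toxicity in this test and lower numbers for higher toxicity in this test), compound 1 `CCCCCCCNc1nc2cc(-c3ccc(C)cc3)sc2c(=O)[nH]1` gives 6800 nM and compound 2 `CCC(CC)Nc1nc2cc(-c3ccc(C)cc3)sc2c(=O)[nH]1` gives 101000 nM as the higher of the two numbers. Compound 3 `Cc1ccc(-c2cc3nc(NC(C)c4ccccc4)[nH]c(=O)c3s2)cc1` differs from compound 2 by 1-phenylethyl in place of pentan-3-yl on a nitrogen on an aromatic ring in a single change at that nitrogen. Among the measured compounds shown here, the only measured step bearing on it is large, a 15-fold higher number from compound 1 to compound 2 (1.17 log units; beyond the scatter) with pentan-3-yl in place of heptyl, so this substituent can move the number widely. For the measured compounds named here, no measured step involves a group with a ring, so direction is tentative. A moderate fall in this assay is expected, with a 2.9-fold lower number from compound 2 to compound 3 (0.46 log units; beyond the scatter) as the estimated step. Compound 3 is estimated at 35000 nM within 9000 nM to 120000 nM on this read-out.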

Compound 3, half-maximal cytotoxic concentration: 9200 nM
Beside the measured number, compound 3's estimate is 3.8-fold (0.58 log units) above it; the measured number falls inside the stated range.
By their numbers in this assay, from the lowest: compounds 1 and 3 (each within the scatter of the next); then compound 2.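

At the nitrogen on an aromatic ring, a group with a six-membered aromatic ring now enters the comparison. In this assay there is an 11-fold lower number from compound 2 to compound 3 (1.04 log units; beyond the scatter) with 1-phenylethyl in place of pentan-3-yl, while a 1.4-fold higher number from compound 1 to compound 3 (0.13 log units; within the scatter) with 1-phenylethyl in place of heptyl, so pentan-3-yl alone stands apart among these three groups. No evidence on the cause of these steps is at hand.
Open, on these data alone, is whether the aromatic ring or the carbon count sets the number of compound 3, and where benzyl or cyclohexyl at this nitrogen would fall.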